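Replacing the methoxy of a carbamate with an acyl urea

The compounds below may be only part of what the source reports. "The series", "measured", "known", "first", "only" and "open" are said of these compounds alone.

Measured compounds:
compound 1, `COC(=O)N1CCCc2cc(S(=O)(=O)N3CC(c4ccccc4)NC3=O)ccc21`: 16500 nM
compound 2, `CC(C)COC(=O)N1CCCc2cc(S(=O)(=O)N3CC(c4ccccc4)NC3=O)ccc21`: 2750 nM

For the measured compounds named here, in a functional assay on cells (KATO III cell, Homo sapiens) for antiproliferative activity, read by MTT assay (on this read-out lower numbers stand for stronger inhibition and higher numbers for weaker inhibition), compound 1 gives 16500 nM, the highest of the two numbers known. Going by the values given here, its nearest neighbour is compound 2, which in this assay gives 2750 nM; the step of a 6.0-fold lower number from compound 1 to compound 2 (0.78 log units; beyond the scatter) is the only measured change at this part of the shared core, and it shows that enlarging the group on the carbonyl carbon lowers the number.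

Compound 3, `O=C(CCl)NC(=O)N1CCCc2cc(S(=O)(=O)N3CC(c4ccccc4)NC3=O)ccc21`, has not been measured. It differs from compound 1 by ((chloromethyl)carbonyl)amino in place of methoxy on a carbonyl carbon. Among the compounds with values here, no measured pair shows this exact exchange, so the expectation rests on compound 1 and on the step of a 6.0-fold lower number from compound 1 to compound 2 (0.78 log units; beyond the scatter) alone, which points to a lower number when this group grows. Since the new group differs in kind and not only in size, the step is expected to be smaller than that one, and a wide range is kept.

The step expected from the exchange is a 2.4-fold lower number from compound 1 to compound 3 (0.37 log units; beyond the scatter). Compound 3 is therefore estimated at 7000 nM, with a range from 2000 nM to 25000 nM.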

Compound 3, half-maximal inhibitory concentration: 2540 nM
Estimate against measurement, compound 3: 2.8-fold (0.44 log units) above; measured number inside the range.
By their numbers in this assay, from the lowest: compounds 3 and 2 (each within the scatter of the next); then compound 1.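

In this assay, ((chloromethyl)carbonyl)amino in place of methoxy on the carbonyl carbon gives a 6.5-fold lower number from compound 1 to compound 3 (0.81 log units; beyond the scatter), so compound 1 now stands apart from two different replacements, each by a step beyond the scatter, and among these three compounds the methoxy group gives the highest number. The result also adds a comparison that the earlier pair could not give: ((chloromethyl)carbonyl)amino in place of isobutoxy gives a 1.1-fold lower number from compound 2 to compound 3 (0.03 log units; within the scatter), which lies within the scatter, so these two groups cannot be told apart in this assay even though only the first holds a hydrogen-bond donor, a chlorine and a second carbonyl. Nothing available here bears on why the two replacements read alike or why both differ from methoxy.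

Going by these compounds, it remains open whether the chlorine plays any part in the number of compound 3, which a plain methyl in place of the chloromethyl would test. On these data alone, it is also open whether a simple amine or a longer alkoxy chain on the same carbonyl carbon would read like these two groups or go lower still.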